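Hydroxy to fluoro on the aromatic ring of the chain

The source may report more compounds than this note shows. Statements on the series, on what has been measured and on what is new or still open speak of the compounds shown alone.

Compound 1 `O=[N+]([O-])c1ccccc1/C=C/C[C@H]1C[C@@H]([C@@H](O)c2ccccc2)CO[C@@H]1c1ccccc1` gives 11800 nM in a functional assay on HeLa cells (Homo sapiens) for cytotoxicity, read by WST assay, with a stated time of 48 h; on this read-out lower numbers stand for stronger inhibition and higher numbers for weaker inhibition. Compound 2 `Oc1ccc(/C=C/C[C@H]2C[C@@H]([C@@H](O)c3ccccc3)CO[C@@H]2c2ccccc2)cc1` gives 14400 nM in this assay, the highest of the two numbers, with its nearest neighbour compound 1 separated by a 1.2-fold higher number from compound 1 to compound 2 (0.09 log units; within the scatter). Compound 3 `O[C@@H](c1ccccc1)[C@H]1CO[C@H](c2ccccc2)[C@@H](C/C=C/c2ccc(F)cc2)C1` differs from compound 2 by fluoro in place of hydroxy on an aromatic carbon. Among the compounds with values here, the only measured step bearing on this, a 1.2-fold higher number from compound 1 to compound 2 (0.09 log units; within the scatter), swapped the whole aryl group at the same chain position and stayed within the scatter, so a single-atom exchange on that ring is expected to move even less. The expected step is a 1.1-fold lower number from compound 2 to compound 3 (0.04 log units; within the scatter), no change beyond the scatter. For compound 3 the estimate in this assay is 13000 nM, range 6000 nM to 28000 nM.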

Compound 3, half-maximal inhibitory concentration: 8340 nM
Estimate against measurement, compound 3: 1.6-fold (0.19 log units) above; low and high end bracket the measured number.
By their numbers in this assay, from the lowest: compounds 3, 1 and 2 (each within the scatter of the next).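

In this assay, fluoro in place of hydroxy on the aromatic carbon gives a 1.7-fold lower number from compound 2 to compound 3 (0.24 log units; within the scatter) and so, at this position, losing the hydrogen-bond donor and acceptor counted for hydroxy leaves the number within the scatter. With a 1.4-fold lower number from compound 1 to compound 3 (0.15 log units; within the scatter) as well, the 2-nitrophenyl, 4-hydroxyphenyl and 4-fluorophenyl compounds cannot be told apart at this end of the chain. Nothing available accounts for this flatness. Still open, from the compounds shown here alone, is whether an amine or a carboxylic acid on that ring, or a longer chain in place of 3-(4-fluorophenyl)prop-2-en-1-yl, would give a step beyond the scatter.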